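The compounds below may be only part of what the source reports. "The series", "measured", "known", "first", "only" and "open" are said of these compounds alone.

Compound 1, `CC(C)[C@H](NC(=O)COc1cccc2ccccc12)C(=O)N[C@@H](CC(=O)O)C(=O)COc1ccccc1`, gives 11200 nM in a functional assay with Homo sapiens as the target; a higher number here means a weaker inhibitor, a lower number a stronger inhibitor. Compound 2, `CC(C)[C@H](NC(=O)COc1cccc2ccccc12)C(=O)N[C@@H](CC(=O)O)C(=O)COc1cccc(F)c1`, gives 12000 nM in the same measurement. Going by the values given here, compound 2 stands as the higher of the two numbers so far, but only nominally: the single step between them, a 1.1-fold higher number from compound 1 to compound 2 (0.03 log units; within the scatter), stays within the scatter, so the two compounds cannot be told apart on these data.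

Compound 3, `CC(C)[C@H](NC(=O)COc1cccc2ccccc12)C(=O)N[C@@H](CC(=O)O)C(=O)COc1ccc(F)c(F)c1F`, has not yet been measured. It differs from compound 2 in one place: 2,3,4-trifluorophenyl in place of 3-fluorophenyl on an oxygen on a saturated carbon. Among the compounds with values here, the only step that bears on this change is the one from compound 1 to compound 2, where adding a fluorine to the same ring moved the number by a 1.1-fold higher number from compound 1 to compound 2 (0.03 log units; within the scatter), which is no movement at all beyond the scatter. Within the data shown here, two further fluorines on that ring have no precedent here, so the account can lean on nothing but that one flat step. The expected step is therefore a 1.1-fold lower number from compound 2 to compound 3 (0.04 log units; within the scatter), with a wide range to reflect how little is known. For compound 3 the estimate in this assay is 11000 nM, expected to fall between 4000 nM and 30000 nM.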

Compound 3, half-maximal inhibitory concentration: 20600 nM
For compound 3 the middle estimate is 1.9-fold (0.27 log units) below the measured one; the measured number falls inside the stated range.
By their numbers in this assay, from the lowest: compounds 1, 2 and 3 (each within the scatter of the next).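

Compound 3 extends the test of this place, on an oxygen on a saturated carbon, from one fluorine to three, and the numbers in this assay still do not separate the compounds: the step is a 1.7-fold higher number from compound 2 to compound 3 (0.23 log units; within the scatter), and measured against the unsubstituted ring it is a 1.8-fold higher number from compound 1 to compound 3 (0.26 log units; within the scatter). Going by these compounds alone, until now, only the single fluorine of compound 2 had been tested, whereas these steps show that neither 3-fluorophenyl nor 2,3,4-trifluorophenyl can be told apart from phenyl on these data, so all three rings are tolerated here to the extent that this measurement can show. No information is available that could explain this result.

The three compounds carry only fluorine as a ring substituent, so they leave open how this assay would respond to an amine or a carboxylic acid on the ring, or to a longer chain in place of the (3-fluorophenoxy)methyl group. They also cannot show what each of the three fluorines of compound 3 contributes alone, or whether any change at this place can move the number beyond the scatter.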